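This account rests on a few compounds, and the source may have more. Where it says the series, first, only, none or still open, it means among the compounds named here.

Series notes, values in a physicochemical assay for lipophilicity, in phosphate buffer, measured as octanol-water partition, at pH 11.5; on this read-out lower numbers stand for lower lipophilicity and higher numbers for higher lipophilicity:

- compound 1 `CCCCCCCCNC(=N)NC(=N)Nc1ccc(C)cc1`: 4.93
- compound 2 `CCCCC(CC)CNC(=N)NC(=N)Nc1ccc(Cl)cc1`: 4.93

Only these two compounds have been measured so far, and they stand level. In this assay, compound 2 gives 4.93, the same reading at the digits shown as compound 1 at 4.93. Among the measured compounds shown here, neither compound sits above the other, and the two differ in more than one place, so the pair gives no single-change step to work from.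

The next compound is compound 3 `CCCCC(CC)CNC(=N)NC(=N)Nc1ccc(C)cc1`, which keeps the chain of compound 2 and has methyl in place of chloro on an aromatic carbon, para to a large group: methyl in place of chloro on an aromatic carbon.

For the measured compounds named here, no measured step isolates that exchange, so the expectation is a judgement anchored on compound 2 at 4.93. The expected change is slightly downward and no larger than the usual scatter, and no step beyond the scatter is expected. The estimated step is a number 0.13 log units lower from compound 2 to compound 3 (within the scatter). For compound 3, the expected value is 4.8, with an estimated range from 4.5 to 5.1.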

Compound 3, partition coefficient: 4.73
Estimate against measurement, compound 3: 0.07 log units above; low and high end bracket the measured number.
By their numbers in this assay, from the lowest: compounds 3, 1 and 2 (each within the scatter of the next).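

In this assay, methyl in place of chloro on an aromatic carbon, para to a large group, now reads as a number 0.20 log units lower from compound 2 to compound 3 (within the scatter) with the branched chain kept unchanged. With 4-methylphenyl kept unchanged, 1-ethylpentyl in place of heptyl on a saturated chain carbon bound to an amine nitrogen reads as a number 0.20 log units lower from compound 1 to compound 3 (within the scatter) and gives the series its second single-change step. Neither exchange therefore moves this read-out beyond the scatter, so at these three compounds neither 4-chlorophenyl against 4-methylphenyl nor the branched chain against the straight one can be told apart. The level pair of compounds 1 and 2 could not give this finding. Those two compounds differ in two places.

The compounds shown leave open whether the same flat picture holds for a methoxy group, a nitro group or a trifluoromethyl group at this position, or for a longer chain at the other end of the shared core. Nothing at hand bears on why either step is as small as it is.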